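Hydroxyphenyl ketones on a shared boron-containing core

The compounds below may be only part of what the source reports. "The series", "measured", "known", "first", "only" and "open" are said of these compounds alone.

Measured so far:
Compound 1 `O=C(/C=C/c1ccc2c(c1)B(O)OC2)c1ccccc1` gives 2300 nM in a functional assay on MDA-MB-231 cells (Homo sapiens) for cytotoxicity, read by MTT assay, with a stated time of 48 h; a lower number here means a stronger inhibitor, a higher number a weaker inhibitor.
Compound 2 `O=C(/C=C/c1ccc2c(c1)B(O)OC2)c1ccco1` gives 7300 nM in this assay.
Compound 3 `O=C(/C=C/c1ccc2c(c1)B(O)OC2)c1ccc(O)cc1` gives 25600 nM in this assay.

Compound 2 stands second highest of the three numbers. Its nearest neighbour is compound 1 with a 3.2-fold higher number from compound 1 to compound 2 (0.50 log units; beyond the scatter); its furthest is compound 3 with a 3.5-fold higher number from compound 2 to compound 3 (0.54 log units; beyond the scatter). The remaining step, an 11-fold higher number from compound 1 to compound 3 (1.05 log units; beyond the scatter), shows the hydroxy group alone at a large cost.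

Compound 4 `O=C(/C=C/c1ccc2c(c1)B(O)OC2)c1ccccc1O` is not yet measured. Relative to compound 2 the change is 2-hydroxyphenyl in place of furan-2-yl on a carbonyl carbon. For the measured compounds named here, two measured steps bear on it. The step of a 3.5-fold higher number from compound 2 to compound 3 (0.54 log units; beyond the scatter) exchanges the same furan-2-yl for a hydroxyphenyl group and gave a modest rise in the number. The step of an 11-fold higher number from compound 1 to compound 3 (1.05 log units; beyond the scatter) shows what a hydroxy group on the phenyl ring did when phenyl was already present. Going by the values given here, both point the same way: the exchange of furan-2-yl for a phenyl bearing hydroxy has so far raised the number beyond the scatter, with no example going the other way. The hydroxy now sits at a different place on the ring, for which no measurement exists, so the size is uncertain.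

Compound 4 is therefore expected to give a higher number than compound 2, with the expected step being a 1.9-fold higher number from compound 2 to compound 4 (0.28 log units; within the scatter). The estimate for compound 4 is 14000 nM, within a range of 4500 nM to 45000 nM.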

Compound 4, half-maximal inhibitory concentration: 16900 nM
Compound 4: middle estimate off by 1.2-fold (0.08 log units), on the low side; the measured number falls inside the stated range.
By their numbers in this assay, from the lowest: compound 1; then compound 2; then compounds 4 and 3 (each within the scatter of the next).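

In this assay, the exchange of 4-hydroxyphenyl for 2-hydroxyphenyl on the carbonyl carbon gives a 1.5-fold lower number from compound 3 to compound 4 (0.18 log units; within the scatter), so the two hydroxy placements cannot be told apart, and the penalty seen earlier is no longer tied to a single hydroxyphenyl compound. A second example of hydroxy in place of hydrogen on an aromatic carbon, a 7.3-fold higher number from compound 1 to compound 4 (0.87 log units; beyond the scatter), shows the same direction as the earlier hydroxy step, and a 2.3-fold higher number from compound 2 to compound 4 (0.36 log units; beyond the scatter) places 2-hydroxyphenyl, like 4-hydroxyphenyl, on the high side of furan-2-yl, so that compound 3 and compound 4 both give higher numbers than compound 1 and compound 2. Nothing available accounts for the penalty that comes with the hydroxy group on the phenyl ring.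

As far as these compounds go, whether this penalty is specific to the hydroxy group remains open, and a methoxy group, an amine or a fluorine on the phenyl ring would address that question. Also open are how 3-hydroxyphenyl would compare with the two hydroxyphenyl groups shown and whether a second hydroxy group on the ring would raise the number further.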